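Compound 4 Estimated from Its Sulfonyl Ring Neighbours

A few compounds are considered here, and "the series" means these few. Any claim that something is new, unique, unknown or untested is made for them only; others in the source may bear on it.

Compound 3 `Cc1ccc2ncc(S(=O)(=O)c3ccc(Cl)cc3)c(N3CCC(C)CC3)c2c1` stands second highest of the three measured compounds in an assay on isolated protein for displacement of a labelled ligand from metabotropic glutamate receptor 5 (Homo sapiens), with a stated time of 60 min, tested at 1 uM (on this read-out higher numbers stand for more inhibition at the one concentration tested (going by the name of the read-out) and lower numbers for less inhibition), where compound 3 gives 79%. Compound 1 `Cc1ccc2ncc(S(=O)(=O)c3ccc(F)cc3)c(N3CCC(C)CC3)c2c1` gives 90%, and compound 2 `COc1ccc(S(=O)(=O)c2cnc3ccc(C)cc3c2N2CCC(C)CC2)cc1` gives 62%. The steps of a number 11 percentage points lower from compound 1 to compound 3 (beyond the scatter) and a number 17 percentage points higher from compound 2 to compound 3 (beyond the scatter) show that exchanging the substituent on the aromatic group on the sulfonyl sulfur shifts the read-out by modest amounts beyond the scatter. Compound 4 `Cc1ccc2ncc(S(=O)(=O)c3ccc(C)c(Cl)c3)c(N3CCC(C)CC3)c2c1` carries 3-chloro-4-methylphenyl in place of 4-chlorophenyl on a sulfonyl sulfur. Among the compounds with values here, no measured step adds a methyl alongside the retained chloro, so the outlook rests on compound 3 alone. Compound 4 is expected to move by a number 5 percentage points lower from compound 3 to compound 4 (within the scatter), a small step near the edge of the scatter. Compound 4 is estimated at 74%, between 55% and 90%.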

Compound 4, a percentage reported as inhibition, at one concentration (the size of the read-out at that concentration, not a potency): 91%
Compound 4: middle estimate off by 17 percentage points, on the low side; the whole stated range lies below it.
By their numbers in this assay, from the lowest: compound 2; then compound 3; then compounds 1 and 4 (each within the scatter of the next).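

In this assay, within the data shown here, exchanging 4-chlorophenyl for 3-chloro-4-methylphenyl on the sulfonyl sulfur gives a number 12 percentage points higher from compound 3 to compound 4 (beyond the scatter), so this position accepts an aryl group carrying two substituents, a case the earlier compounds, each with one, did not cover. Against 4-methoxyphenyl, the same group gives a number 29 percentage points higher from compound 2 to compound 4 (beyond the scatter). Against 4-fluorophenyl, it gives a number 1 percentage points higher from compound 1 to compound 4 (within the scatter), so these two groups cannot be told apart here.

Whether the methyl or the altered chloro placement accounts for the step from the 4-chlorophenyl compound stays open, as does the outcome with an amine or a carboxylic acid on this ring. No available evidence explains these steps.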